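Isobutyl for cyclopropyl on the core of compound 2

A few compounds are considered here, and "the series" means these few. Any claim that something is new, unique, unknown or untested is made for them only; others in the source may bear on it.

Measured so far:
compound 1, `CC(C)CCn1sc2cc(OCc3cccc(-c4ccc(Cl)c(C(=O)O)c4)c3)ccc2c1=O`, 67.3%
compound 2, `O=C(O)c1cc(-c2cccc(COc3ccc4c(=O)n(C5CC5)sc4c3)c2)ccc1Cl`, 70.6%

In an assay on HEK293 cells for positive allosteric modulation of metabotropic glutamate receptor 2 (Rattus norvegicus), read by thallium flux (a higher number here means a larger maximal response, a lower number a smaller maximal response), compound 1 gives 67.3% and compound 2 gives 70.6%. These two numbers cannot be told apart: the step of a number 3.3 percentage points higher from compound 1 to compound 2 (within the scatter) lies within the scatter, so compound 2 stands level with compound 1 in this assay rather than above it.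

Compound 3, `CC(C)Cn1sc2cc(OCc3cccc(-c4ccc(Cl)c(C(=O)O)c4)c3)ccc2c1=O`, is not yet measured. It differs from compound 2 as follows: isobutyl in place of cyclopropyl on an aromatic nitrogen. Among the compounds with values here, only one measured step bears on this place, a number 3.3 percentage points higher from compound 1 to compound 2 (within the scatter), which exchanged two groups at the same aromatic nitrogen and stayed within the scatter. On that basis no step beyond the scatter is expected in this assay for the change to isobutyl.

Compound 3 is therefore expected to give about 68% in this assay, estimated between 58% and 78%, an expected step of a number 2.6 percentage points lower from compound 2 to compound 3 (within the scatter).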

Compound 3, largest response reached (reported as percent of maximum), in percent of the reference or control that the assay uses: 76.2%
Beside the measured number, compound 3's estimate is 8.2 percentage points below it, within the range that was stated.
By their numbers in this assay, from the lowest: compounds 1, 2 and 3 (each within the scatter of the next).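

In this assay, moving from the three-membered ring of cyclopropyl to the open isobutyl chain stays within the scatter (a number 5.6 percentage points higher from compound 2 to compound 3 (within the scatter)), so a ring at this aromatic nitrogen is not needed for the maximal response. Exchanging one open chain for another at the same place also stays within the scatter (a number 8.9 percentage points higher from compound 1 to compound 3 (within the scatter)), which leaves isopentyl, cyclopropyl and isobutyl level with one another at this position. No measurement at hand explains why these groups stand level.

Going by these compounds, whether this tolerance extends to a much smaller group such as methyl, or to a longer chain, remains open. So does the effect of a chain ending in an amine or a hydroxyl group at this nitrogen.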